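Swapping an Acid for a Cyclopentylmethyl Group

A few compounds are considered here, and "the series" means these few. Any claim that something is new, unique, unknown or untested is made for them only; others in the source may bear on it.

Three amides built on a shared core have been measured in an assay on HEK293 cells for displacement of a labelled ligand from metabotropic glutamate receptor 5 (Rattus norvegicus); a lower number here means a stronger inhibitor, a higher number a weaker inhibitor. Compound 1 `O=C(Nc1cc(-c2ccccc2)nn1-c1ccccc1)c1ccccc1` carries a plain benzoyl group and gives 4180 nM. Compound 2 `COc1ccc(C(=O)Nc2cc(-c3ccccc3)nn2-c2ccccc2)cc1` adds a methoxy group on an aromatic carbon and gives 420 nM. That change gives a 10-fold lower number from compound 1 to compound 2 (1.00 log units; beyond the scatter). Compound 3 `O=C(O)c1ccc(C(=O)Nc2cc(-c3ccccc3)nn2-c2ccccc2)cc1` carries a carboxy group on an aromatic carbon instead. In this assay compound 3 gives only a limit, > 10000 nM, and not a number. Compound 3 sits at the limit of > 10000 nM in this assay, at which 1 of the 3 values shown sits, which makes it the weakest of the three on the numbers shown, with an at least 2.3-fold higher number from compound 1 to compound 3 (0.37 log units; beyond the scatter) and an at least 23-fold higher number from compound 2 to compound 3 (1.37 log units; beyond the scatter).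

Compound 4 `O=C(CC1CCCC1)Nc1cc(-c2ccccc2)nn1-c1ccccc1` differs from compound 3 by cyclopentylmethyl in place of 4-carboxyphenyl on a carbonyl carbon. The two measured steps that bear on this change are the ones in which the carboxy group entered, and both raised the number; compound 4 removes that group entirely. Going by the values given here, the entering cyclopentylmethyl group resembles none of the measured groups, so the size of the reversal is uncertain, but a clear drop in the number is expected. Compound 4 is therefore estimated at 2000 nM, within a range from 300 nM to 10000 nM, which corresponds to an expected step of an at least 5.0-fold lower number from compound 3 to compound 4 (0.69 log units; beyond the scatter).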

Compound 4, inhibition constant: > 10000 nM
Compound 4 was reported as a limit; the forecaster's own chance of this, stated with the estimate: 15%; middle value at least 5.0-fold (0.69 log units) away from the limit.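

Compound 4 gives > 10000 nM in this assay, a limit and not a number, so taking away the carboxy group does not by itself bring the number down. Cyclopentylmethyl in place of phenyl gives an at least 2.3-fold higher number from compound 1 to compound 4 (0.37 log units; beyond the scatter), and in place of 4-methoxyphenyl it gives an at least 23-fold higher number from compound 2 to compound 4 (1.37 log units; beyond the scatter), so on this carbonyl carbon both aromatic groups do better than this non-aromatic ring, and the weak end of the series is no longer held by the carboxy compound alone. The step between compound 3 and compound 4 cannot be read, because both sit at the same limit: the limit of > 10000 nM in this assay, at which 2 of the 4 values shown sit.

As far as these compounds go, what remains open is whether the loss of the aromatic ring or the extra carbon linking the ring to the carbonyl carbon accounts for the higher number, a question that a cyclohexyl group and a benzyl group on that carbonyl carbon would help to separate. From the compounds shown here alone, it is also open how much the phenyl ring can carry in place of methoxy, for example an ethoxy group, a longer chain or an amine.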